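A few compounds are considered here, and "the series" means these few. Any claim that something is new, unique, unknown or untested is made for them only; others in the source may bear on it.

Measured so far in an ADME assay on HFF cells (Homo sapiens) for cytotoxicity; a lower number here means a stronger inhibitor, a higher number a weaker inhibitor:
- compound 1 `N#Cc1cn(COC(CO)CO)c2ncnc(N)c12` gives > 320000 nM as a limit
- compound 2 `N/C(=N\O)c1cn(COC(CO)CO)c2ncnc(N)c12` gives > 100000 nM as a limit
- compound 3 `N#Cc1cn(C(CO)OC(CO)CO)c2ncnc(N)c12` gives > 100000 nM as a limit

Compound 2 stands at > 100000 nM in this assay, which is a limit. For the measured compounds named here, the series holds only the limit of > 100000 nM in this assay, at which 2 of the 3 values shown sit, and the limit of > 320000 nM in this assay, at which 1 of the 3 values shown sits, and no true number so far.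

The next structure is compound 4 `Nc1ncnc2c1ccn2COC(CO)CO`, not yet measured. The change is a hydrogen atom in place of a group of 4 heavy atoms (1 carbon, 2 nitrogen, 1 oxygen; no ring), on an aromatic carbon and it removes the whole group from that aromatic carbon.

Going by the values given here, two measured steps bear on this. Among the compounds with values here, the first is a step that the two limits leave unreadable from compound 1 to compound 2 and it changes the group on the same aromatic carbon. The second is a step that the two limits leave unreadable from compound 1 to compound 3 and it changes the saturated chain instead. Neither gives a size to carry over. The estimated a number no higher from compound 2 to compound 4 (the limit leaves the size open) is therefore taken as no more than the usual scatter, in no set direction.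

For compound 4 the expected value is 100000 nM, with an estimated range from 40000 nM to 320000 nM and a report as a limit quite likely.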

Compound 4, half-maximal inhibitory concentration: > 100000 nM
Compound 4 ended at the assay's limit; the forecaster's own chance of this, stated with the estimate: 80%; the middle value sits exactly at the limit.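

In this assay compound 4 gives > 100000 nM, which is a limit, so the steps to it from compound 1 and from compound 2 cannot be read. The compounds shown leave open where a true value for any member of the series lies in this assay.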